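Aryl sulfamate series: shortening the dimethylamino chain

The compounds below may be only part of what the source reports. "The series", "measured", "known", "first", "only" and "open" are said of these compounds alone.

Measured so far:
compound 1, `CN(C)CCCN(Cc1ccccc1)c1cccc(C(=O)N2CCc3ccc(OS(N)(=O)=O)cc3C2)c1`, 26%
compound 2, `CN(C)CCN(Cc1ccccc1)c1cccc(C(=O)N2CCc3ccc(OS(N)(=O)=O)cc3C2)c1`, 28.6%
compound 3, `CN(C)CCCN(Cc1ccccc1)c1ccc(C(=O)N2CCc3ccc(OS(N)(=O)=O)cc3C2)cc1`, 61.6%

All three share the sulfamate-bearing core and differ in the benzylamino side arm. In an assay on HEK293 cells for inhibition of Steryl-sulfatase (Homo sapiens), tested at 1 uM (on this read-out lower numbers stand for a weaker effect and higher numbers for a stronger effect at the one concentration tested), compound 1 gives 26% and compound 2 gives 28.6%. The change between them is dimethylamino in place of (dimethylamino)methyl on a saturated chain carbon, two bonds along the chain from a nitrogen on an aromatic ring, and the step it made, a number 2.6 percentage points higher from compound 1 to compound 2 (within the scatter), is within the scatter. Compound 3 carries the same side arm as compound 1 but attached to the core differently; the difference between the two cores is not broken down here. In this assay compound 3 gives 61.6%, the highest of the three numbers, beyond the scatter from both compound 1 and compound 2.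

Compound 4, `CN(C)CCN(Cc1ccccc1)c1ccc(C(=O)N2CCc3ccc(OS(N)(=O)=O)cc3C2)cc1`, is not yet measured. It differs from compound 3 by dimethylamino in place of (dimethylamino)methyl on a saturated chain carbon, two bonds along the chain from a nitrogen on an aromatic ring, which is the same change as from compound 1 to compound 2, occurring in two pairs among the compounds shown. Because a number 2.6 percentage points higher from compound 1 to compound 2 (within the scatter) was within the scatter, the expectation is that the step of a number 0.4 percentage points higher from compound 3 to compound 4 (within the scatter) is also small, and that compound 4 stays near compound 3 rather than near compound 1 or compound 2. For the measured compounds named here, the estimate for compound 4 in this assay is 62%, with a range from 46% to 76%, resting on the single earlier instance of this change.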

Compound 4, a percentage reported as inhibition, at one concentration (the size of the read-out at that concentration, not a potency) in the Steryl-sulfatase assay: 57.8%
Estimate against measurement, compound 4: 4.2 percentage points above; measured number inside the range.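

Across the two cores, the change from 3-(dimethylamino)propyl to 2-(dimethylamino)ethyl carries over without a readable effect. In the Steryl-sulfatase assay the new step is a number 3.8 percentage points lower from compound 3 to compound 4 (within the scatter), and it agrees with the earlier step on the other core: the same change on two cores in the Steryl-sulfatase assay, a number 2.6 percentage points higher (within the scatter) from compound 1 to compound 2 and a number 3.8 percentage points lower (within the scatter) from compound 3 to compound 4, 6.4 percentage points apart, within the scatter of two such steps

In a physicochemical assay for lipophilicity (a lower number here means a more polar compound, a higher number a more lipophilic compound), the same change gives no change at the digits printed from compound 3 to compound 4 (within the scatter), with compound 3 at 1.93 and compound 4 at 1.93. For the compounds shown here, this rests on only two pairs and on a read-out taken at one concentration, so it does not show that the change is without effect on any other core, and a shift smaller than the scatter, or one visible only in a full potency measurement, would go unseen here.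

The compounds shown leave open whether the same tolerance extends to a longer chain such as 4-(dimethylamino)butyl, or to a different end group, such as a morpholine, a primary amine or a carboxylic acid, in place of dimethylamino. They also leave open what happens when the benzyl group on the aromatic nitrogen is replaced, for example by a methyl group or a hydrogen.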